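Butyl Extension on Two Cores in a Lipophilicity Assay

The source may report more compounds than this note shows. Statements on the series, on what has been measured and on what is new or still open speak of the compounds shown alone.

Compound 1 `CC#CCn1c(N2CCC[C@@H](N)C2)cc(=O)n(CCCCCC)c1=O` gives 2.15 in a physicochemical assay for lipophilicity; a lower number here means a more polar compound, a higher number a more lipophilic compound. Compound 2 `CC#CCn1c(N2CCC[C@@H](N)C2)cc(=O)n(CCCCCCCCCC)c1=O` gives 3.82, and the step of a number 1.67 log units higher from compound 1 to compound 2 (beyond the scatter) follows the change (butyl in place of hydrogen on a saturated chain carbon, six bonds along the chain from an aromatic nitrogen). Compound 3 `CCCCCCn1c(=O)cc(N2CCC[C@@H](N)C2)n(Cc2cc(F)ccc2C#N)c1=O` differs from compound 1 in its core by 2-cyano-5-fluorophenyl in place of prop-1-yn-1-yl on a saturated chain carbon bound to an aromatic nitrogen, and in this assay compound 3 gives 3.26, a step of a number 1.11 log units higher from compound 1 to compound 3 (beyond the scatter). Compound 4 `CCCCCCCCCCn1c(=O)cc(N2CCC[C@@H](N)C2)n(Cc2cc(F)ccc2C#N)c1=O` is not yet measured; it differs from compound 3 by butyl in place of hydrogen on a saturated chain carbon, six bonds along the chain from an aromatic nitrogen, the same change that carried compound 1 to compound 2, at the same place. Because that step was a number 1.67 log units higher from compound 1 to compound 2 (beyond the scatter), a similar step is expected on the core of compound 3, estimated as a number 1.59 log units higher from compound 3 to compound 4 (beyond the scatter). Compound 4 is therefore expected to read about 4.85, plausibly between 4.4 and 5.3.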

Compound 4, partition coefficient: 4.93
Beside the measured number, compound 4's estimate is 0.08 log units below it, and the stated range covers the measured number.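

In this assay the butyl extension gave a step on the core of compound 3 (a number 1.67 log units higher from compound 3 to compound 4 (beyond the scatter)) equal in size to the one on the core of compound 1 (a number 1.67 log units higher from compound 1 to compound 2 (beyond the scatter)), and the exchange of prop-1-yn-1-yl for 2-cyano-5-fluorophenyl likewise read the same on the longer chain (a number 1.11 log units higher from compound 2 to compound 4 (beyond the scatter)) as on the shorter one (a number 1.11 log units higher from compound 1 to compound 3 (beyond the scatter)). This shows that the change carried over unchanged between these two cores, but two cores and one chain extension do not show that it would carry to any other core. Nothing shown explains this agreement.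

As far as these compounds go, it remains open whether a longer chain at this place would extend the same step. From the compounds shown here alone, it is also open whether an amine or a carboxylic acid at the end of the chain would carry equally between the two cores.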